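A few compounds are considered here, and "the series" means these few. Any claim that something is new, unique, unknown or untested is made for them only; others in the source may bear on it.

Measured so far in a functional assay on HL-60 cells (Homo sapiens) for antiproliferative activity, read by MTT assay, with a stated time of 72 h; a lower number here means a stronger inhibitor, a higher number a weaker inhibitor
compound 1 `NC1=NC2(CCOCC2)N(OCCCOc2ccccc2)C(N)=N1` gives 2460 nM
compound 2 `COc1ccc(OCCCON2C(N)=NC(N)=NC23CCOCC3)cc1` gives 1670 nM
compound 3 `NC1=NC2(CCSCC2)N(OCCCOc2cccc(Cl)c2)C(N)=N1` gives 260 nM

Compound 2 at 1670 nM lies within the scatter of compound 1, while compound 3 gives a clearly lower number. The next compound to consider is compound 4 `NC1=NC2(CCOCC2)N(OCCCOc2ccc(Cl)cc2)C(N)=N1`, which differs from compound 2 in a single place (chloro in place of methoxy on an aromatic carbon): chloro in place of methoxy on an aromatic carbon.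

Among the measured compounds shown here, only one measured step bears directly on this change. It swaps a single group on the aromatic ring, putting methoxy in place of hydrogen on an aromatic carbon (a 1.5-fold lower number from compound 1 to compound 2 (0.17 log units; within the scatter)), and that step stays within the scatter. Compound 3 also carries a chloro, but it differs from compound 4 in more than one place, so its lower number cannot be credited to chloro alone. For the measured compounds named here, no measured step isolates that group.

Going by the values given here, on this evidence, no step clearly beyond the scatter is expected in this assay, although compound 3 at 260 nM leaves room for a somewhat lower number. The expected change is a 1.7-fold lower number from compound 2 to compound 4 (0.22 log units; within the scatter) and remains an estimate only. For compound 4 the estimated value is 1000 nM with an expected range from 350 nM to 2500 nM in this assay.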

Compound 4, half-maximal inhibitory concentration: 330 nM
The estimate for compound 4 lay 3.0-fold (0.48 log units) above the measured number; measured number outside the range, below it.
By their numbers in this assay, from the lowest: compounds 3 and 4 (each within the scatter of the next); then compounds 2 and 1 (each within the scatter of the next).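

The change from 4-methoxyphenyl to 4-chlorophenyl shows that, in this assay, the group at this place on the aromatic ring, para to a large group, can clearly shift the number: the swap gives a 5.1-fold lower number from compound 2 to compound 4 (0.70 log units; beyond the scatter). The earlier step at this place, a 1.5-fold lower number from compound 1 to compound 2 (0.17 log units; within the scatter), stayed within the scatter, so it gave no sign of such a shift. Taking hydrogen as the reference, chloro gives a 7.5-fold lower number from compound 1 to compound 4 (0.87 log units; beyond the scatter), which shows that at this place on the shared core, chloro and methoxy are not interchangeable, although nothing measured here explains why they differ.

As far as these compounds go, only hydrogen, methoxy and chloro are compared at this place, so it remains open whether a fluoro, a bromo, a trifluoromethyl or an amine there would give a number closer to that of chloro or to that of methoxy. From the compounds shown here alone, compound 3 also carries a chloro but differs from compound 4 in more than one place, so the separate contributions of those differences also remain open.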